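The source may report more compounds than this note shows. Statements on the series, on what has been measured and on what is new or still open speak of the compounds shown alone.

Compound 1 `COc1ccc2c(c1)OC(c1cc(OC)c(OC)c(OC)c1)C(C(=O)OC(C)(C)C)=C2` is the reference point of this small set. In a functional assay for inhibition of nuclear factor NF-kappa-B complex (Homo sapiens) (on this read-out lower numbers stand for stronger inhibition and higher numbers for weaker inhibition), compound 1 gives 14100 nM, the lower of the two plain numbers shown, though the gap to compound 2 lies within the scatter. Compound 2 `COc1ccc2c(c1)OC(c1cc(OC)c(OC)c(OC)c1)C(C(=O)Nc1ccccc1)=C2` carries anilino in place of tert-butoxy on a carbonyl carbon, and in this assay compound 2 gives 17500 nM; the step of a 1.2-fold higher number from compound 1 to compound 2 (0.09 log units; within the scatter) stays within the scatter. Compound 3 `COc1ccc2c(c1)OC(c1cc(OC)c(OC)c(OC)c1)C(C(=O)NC(C)C)=C2` carries isopropylamino in place of tert-butoxy on a carbonyl carbon. For compound 3 this assay reports only a limit, > 50000 nM, which is the limit of > 50000 nM in this assay, at which 1 of the 3 values shown sits. The step of an at least 3.5-fold higher number from compound 1 to compound 3 (0.54 log units; beyond the scatter) and the step of an at least 2.8-fold higher number from compound 2 to compound 3 (0.45 log units; beyond the scatter) both lie beyond the scatter.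

Compound 4 `COc1ccc2c(c1)OC(c1cc(OC)c(OC)c(OC)c1)C(CO)=C2` differs from compound 1 by hydroxymethyl in place of tert-butoxycarbonyl on a double-bonded ring carbon. Among the compounds with values here, none of the measured steps covers this change directly: all three keep a carbonyl on the double-bonded ring carbon and vary only the group attached to it, whereas here the tert-butoxycarbonyl leaves altogether and a much smaller hydroxymethyl enters. What the measured steps do show is that the tert-butoxy variant gives the lowest number and that both replacements gave an equal or a higher one. For compound 4 the expected step is a 1.8-fold higher number from compound 1 to compound 4 (0.25 log units; within the scatter). In this assay compound 4 is estimated at 25000 nM, within a range from 8000 nM to 60000 nM, and a limit rather than a number would not be surprising.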

Compound 4, half-maximal inhibitory concentration: > 50000 nM
Compound 4 ended at the assay's limit; the forecaster's own chance of this, stated with the estimate: 35%; middle value at least 2.0-fold (0.30 log units) away from the limit.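

In this assay compound 4 gives only a limit, > 50000 nM, and it shares this limit with compound 3: the limit of > 50000 nM in this assay, at which 2 of the 4 values shown sit.

The earlier compounds shown here varied only the group attached to the carbonyl, whereas this change removes the whole tert-butoxycarbonyl and shows that hydroxymethyl on this double-bonded ring carbon does not keep the level of the two plain numbers: an at least 3.5-fold higher number from compound 1 to compound 4 (0.54 log units; beyond the scatter) and an at least 2.8-fold higher number from compound 2 to compound 4 (0.45 log units; beyond the scatter) both lie beyond the scatter. Among the four compounds shown, only tert-butoxycarbonyl and phenylcarbamoyl at this position give plain numbers, while the step from compound 3 to compound 4 cannot be read, as both values are limits.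

Hydroxymethyl differs from tert-butoxycarbonyl in both size and the presence of a carbonyl, so the compounds shown do not separate these two changes, and the limits do not tell how far compound 3 and compound 4 lie from each other. On these data alone, it also remains open whether a carboxylic acid, a methyl ester or an aminomethyl group on the same carbon would give a plain number in this assay.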